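Benzyl on the amide-type nitrogen: the step to compound 4

This account rests on a few compounds, and the source may have more. Where it says the series, first, only, none or still open, it means among the compounds named here.

Measured in a functional assay on Jurkat cells (Homo sapiens) for antiproliferative activity, read by MTT assay, with a stated time of 48 h; on this read-out higher numbers stand for weaker inhibition and lower numbers for stronger inhibition:
- compound 1 `CCCCc1ccc2c(c1)C(=O)C(=O)N2`: > 10000 nM (a limit of the assay, not a number)
- compound 2 `COC(=O)/C=C/c1ccc2c(c1)C(=O)C(=O)N2`: 200 nM
- compound 3 `COC(=O)/C=C/c1ccc2c(c1)C(=O)C(=O)N2Cc1ccccc1`: 70 nM

Compound 3 holds the lower of the two actual numbers at 70 nM, while compound 2 stands at 200 nM. Compound 1 gives only a limit, > 10000 nM.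

The next compound, compound 4 `COC(=O)/C=C/c1ccc2c(c1)C(=O)C(=O)N2Cc1ccc(Cl)c(Cl)c1`, has 3,4-dichlorophenyl in place of phenyl on a saturated chain carbon bound to an amide-type nitrogen in a ring.

Among the measured compounds shown here, one measured step bears on this change, because it concerns the same nitrogen: a 2.9-fold lower number from compound 2 to compound 3 (0.46 log units; beyond the scatter). That step is modest but beyond the scatter, and it runs toward a lower number. For the measured compounds named here, no measured compound carries any substituent on the phenyl ring, so the direction of the new change is an extrapolation from that single step. A further small gain is expected, no larger than the one seen on adding benzyl, and it may barely clear the scatter.

The step expected in this assay is a 2.0-fold lower number from compound 3 to compound 4 (0.30 log units; within the scatter). For compound 4 the estimated value is 35 nM, with an expected range from 12 nM to 100 nM.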

Compound 4, half-maximal inhibitory concentration: 850 nM
Beside the measured number, compound 4's estimate is 24-fold (1.39 log units) below it, outside the stated range (above it).
By their numbers in this assay, from the lowest: compound 3; then compound 2; then compound 4. At a limit, above all of these: compound 1.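

In this assay, 3,4-dichlorophenyl in place of phenyl on a saturated chain carbon bound to an amide-type nitrogen in a ring gives a 12-fold higher number from compound 3 to compound 4 (1.08 log units; beyond the scatter). This large step runs in the opposite direction to the modest one on adding benzyl, a 2.9-fold lower number from compound 2 to compound 3 (0.46 log units; beyond the scatter), so the gain seen with benzyl at this nitrogen does not carry over to the dichlorinated ring. The earlier compounds showed only that this nitrogen could take a benzyl group; compound 4 shows that the number here also depends strongly on what the phenyl ring carries, and nothing among the data shown accounts for the reversal.

Going by these compounds, whether the loss needs both chlorines or follows from one stays open, as does the outcome with a single chlorine, a single fluorine or a methoxy group on the phenyl ring. Also open, on these data alone, is how a longer chain carrying the phenyl ring, or an amine or carboxylic acid on that ring, would read in this assay.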